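A few compounds are considered here, and "the series" means these few. Any claim that something is new, unique, unknown or untested is made for them only; others in the source may bear on it.

Notes on the series: three compounds share a core and have been tested in a functional assay on DU-145 cells (Homo sapiens) for cytotoxicity, read by MTT assay, with a stated time of 72 h; a higher number here means a weaker inhibitor, a lower number a stronger inhibitor.

Compound 1 `COc1cc(-c2cncc(N[C@@H](C)c3ccccc3)n2)ccc1O` gives 3000 nM in this assay. Compound 2 `CCC[C@H](Nc1cncc(-c2ccc(O)c(OC)c2)n1)c1ccccc1` gives 200 nM. Compound 3 `CCCC(Nc1cncc(-c2ccc(O)c(OC)c2)n1)c1ccccc1` gives 500 nM. Compound 3 therefore stands second highest of the three numbers: its nearest neighbour is compound 2, the step being a 2.5-fold higher number from compound 2 to compound 3 (0.40 log units; beyond the scatter), a step that rests only on the drawing of the stereocentre (the fact that one of compounds 2 and 3 is drawn with a defined configuration and the other without, at the place where they differ); its furthest is compound 1, whose number is higher than that of compound 3. Within the data shown here, the one large measured step, a 15-fold lower number from compound 1 to compound 2 (1.18 log units; beyond the scatter), concerns the saturated chain next to the amine, not the phenyl ring.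

Compound 4 `CCCC(Nc1cncc(-c2ccc(O)c(OC)c2)n1)c1ccc(Cl)cc1` differs from compound 3 by chloro in place of hydrogen on an aromatic carbon, which read one bond further out is phenyl to 4-chlorophenyl. Among the measured compounds shown here, no measured step touches this aromatic ring, so neither the large chain step nor the modest stereo step bears directly on it. In this assay no step beyond the scatter is expected from compound 3 to compound 4, the estimated step being a 1.3-fold lower number from compound 3 to compound 4 (0.10 log units; within the scatter). For the measured compounds named here, compound 4 is therefore estimated at 400 nM, with a range from 120 nM to 1500 nM, the width reflecting that the ring has not yet been varied.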

Compound 4, half-maximal inhibitory concentration: 10000 nM
Compound 4: the middle estimate sits 25-fold (1.40 log units) below what was measured; measured number outside the range, above it.
By their numbers in this assay, from the lowest: compound 2; then compound 3; then compound 1; then compound 4.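

In this assay, among these compounds, the earlier compounds left the phenyl ring unvaried, and this first change there is not neutral: with chloro in place of hydrogen para to a large group, the result is a 20-fold higher number from compound 3 to compound 4 (1.30 log units; beyond the scatter). Compound 3 and compound 4 are both drawn without a configuration at the chain stereocentre, so the step does not rest on the drawing, and a single heavy atom on the ring moves the number the opposite way from the ethyl change on the chain, a 15-fold lower number from compound 1 to compound 2 (1.18 log units; beyond the scatter). Nothing at hand bears on the origin of this step.

On these data alone, whether the weakening belongs to chloro itself or to any group at this ring position stays open, and fluoro, methyl or methoxy in the same place, or chloro elsewhere on the ring, would separate those readings. Also open, as far as these compounds go, is whether 4-chlorophenyl behaves the same with the configuration drawn as in compound 2, or with a longer chain in place of the propyl chain of compound 4.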